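The source may hold more compounds than are shown below. What is called first, only, known or untested is meant among the compounds shown, and "the series" means these compounds.

Compound 1 `COc1cccc(N2C(=O)COc3ccc(-c4cnc(Cl)c(NS(=O)(=O)c5ccc(F)cc5)c4)cc32)c1`: in a functional assay on A-375 cells (Homo sapiens) for antiproliferative activity, read by MTT assay, with a stated time of 72 h (a lower number here means a stronger inhibitor, a higher number a weaker inhibitor), compound 1 gives > 40000 nM, which is a limit of the assay.
Compound 2 `O=C1COc2ccc(-c3cnc(Cl)c(NS(=O)(=O)c4ccc(F)cc4)c3)cc2N1c1ccc(F)cc1`: in this assay compound 2 gives > 40000 nM, again a limit.
Compound 3 `COc1ncc(-c2ccc3c(c2)N(c2ccc(F)cc2)C(=O)CO3)cc1NS(=O)(=O)c1ccc(F)cc1`: in this assay compound 3 gives > 40000 nM, also a limit.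

Compound 2 therefore stands at the limit shared by every value here, (the limit of > 40000 nM in this assay, at which 3 of the 3 values shown sit). The change to compound 4 `Cc1ccc(N2C(=O)COc3ccc(-c4cnc(Cl)c(NS(=O)(=O)c5ccc(F)cc5)c4)cc32)cc1` is methyl in place of fluoro on an aromatic carbon. The measured steps that bear on it, a step that the two limits leave unreadable from compound 1 to compound 2 and a step that the two limits leave unreadable from compound 2 to compound 3, are both unreadable, so no size or direction can be drawn from them for compound 4 in this assay; the expected step of a number no higher from compound 2 to compound 4 (the limit leaves the size open) is no change beyond the scatter. The estimate for compound 4 in this assay is 40000 nM, with a range from 15000 nM to 100000 nM, most likely reported again as a limit.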

Compound 4, half-maximal inhibitory concentration: 38900 nM
Beside the measured number, compound 4's estimate is 1.0-fold (0.01 log units) above it; the measured number falls inside the stated range.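

In this assay compound 4 gives a readable number, 38900 nM. Compound 2 remains at a limit of the assay, as do compounds 1 and 3: the limit of > 40000 nM in this assay, at which 3 of the 4 values shown sit.

The two steps, an at least 1.0-fold lower number from compound 2 to compound 4 (0.01 log units; that floor lies within the scatter) and an at least 1.0-fold lower number from compound 1 to compound 4 (0.01 log units; that floor lies within the scatter), therefore show no gain beyond the scatter at their floors, so methyl at this place has not been shown to differ from fluoro.

As far as these compounds go, how far the true number of compound 2 lies from that of compound 4 stays open. So does what an amine, a carboxylic acid or a longer chain would give at this place.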